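Carbamate side chain shortened: from hexyl to trifluoroethyl

The source may hold more compounds than are shown below. What is called first, only, known or untested is meant among the compounds shown, and "the series" means these compounds.

Measured compounds:
compound 1 `COc1cc(NC(C)CCCNC(=O)Oc2ccc(Cl)cc2)c2ncccc2c1` gives 4.44;
compound 2 `COc1ccc(OC(=O)NCCCC(C)Nc2cc(OC)cc3cccnc23)cc1` gives 4.23;
compound 3 `CCCCCCOC(=O)NCCCC(C)Nc1cc(OC)cc2cccnc12` gives 4.64.

All three were read in a physicochemical assay for lipophilicity, read by HPLC, in phosphate buffer, measured as octanol-water partition, with a stated time of 30 min, at pH 7.4; on this read-out lower numbers stand for lower lipophilicity and higher numbers for higher lipophilicity. Compound 3 stands highest of the three numbers on this assay, with compound 1 nearest, and compound 2 furthest from it. The step of a number 0.20 log units higher from compound 1 to compound 3 (within the scatter) and the step of a number 0.41 log units higher from compound 2 to compound 3 (beyond the scatter) both swap the group on the oxygen next to the carbonyl group, and both move the number in the same direction, with only the second reaching beyond the scatter. The step of a number 0.21 log units lower from compound 1 to compound 2 (within the scatter) touches a different place.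

Compound 4 `COc1cc(NC(C)CCCNC(=O)OCC(F)(F)F)c2ncccc2c1` is not yet measured. Its difference from compound 3 is trifluoromethyl in place of pentyl on a saturated chain carbon bound to an oxygen next to a carbonyl group. Among the compounds with values here, no measured step swaps a saturated chain for a trifluoromethyl at this place, so the two steps ending at compound 3 give only a sense of how much the group on this oxygen can move the number. Since five chain carbons leave and a trifluoromethyl enters, compound 4 is expected to sit clearly lower than compound 3, by the step of a number 1.34 log units lower from compound 3 to compound 4 (beyond the scatter). Compound 4 is therefore estimated at 3.3, within a range from 2.7 to 3.9.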

Compound 4, distribution coefficient: 3.41
For compound 4 the middle estimate is 0.11 log units below the measured one; low and high end bracket the measured number.
By their numbers in this assay, from the lowest: compound 4; then compounds 2, 1 and 3 (each within the scatter of the next, the first and the last beyond it).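

The earlier compounds shown here showed the group on this oxygen moving the number in this assay only within a narrow band, with hexyl, 4-chlorophenyl and 4-methoxyphenyl all close together and the widest step being a number 0.41 log units higher from compound 2 to compound 3 (beyond the scatter) at this place. With 2,2,2-trifluoroethyl on the same oxygen the position proves able to carry a much larger shift: against hexyl the change gives a number 1.23 log units lower from compound 3 to compound 4 (beyond the scatter) while against 4-chlorophenyl it gives a number 1.03 log units lower from compound 1 to compound 4 (beyond the scatter) and against 4-methoxyphenyl it gives a number 0.82 log units lower from compound 2 to compound 4 (beyond the scatter) so that compound 4 stands lowest of the four, beyond the scatter of each of the others. Nothing at hand accounts for the size of this fall.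

The compounds shown leave open whether the fall goes with the shorter chain or with the three fluorines, a question that a plain ethyl or a butyl on this oxygen would help to separate. They also leave open how the number would respond to a 2-hydroxyethyl or a 2-aminoethyl group at the same place, or to a longer fluorinated chain.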